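Chloro in place of bromo: an expected small step

The compounds below may be only part of what the source reports. "The series", "measured", "known", "first", "only" and "open" are said of these compounds alone.

compound 1 `Cc1ccc(/C=C2\SC(=O)N(CC(=O)Nc3c(C)n(C)n(-c4ccccc4)c3=O)C2=O)cc1` gives 65500 nM
compound 2 `Cc1c(NC(=O)CN2C(=O)S/C(=C\c3ccc([N+](=O)[O-])cc3)C2=O)c(=O)n(-c2ccccc2)n1C` gives 82400 nM
compound 3 `Cc1c(NC(=O)CN2C(=O)S/C(=C\c3ccc(Br)cc3)C2=O)c(=O)n(-c2ccccc2)n1C` gives 24100 nM

In a functional assay on MCF7 cells (Homo sapiens) for inhibition, read by MTT assay, with a stated time of 48 h (a lower number here means a stronger inhibitor, a higher number a weaker inhibitor), compound 3 stands lowest of the three numbers, with compound 1 its nearest neighbour and compound 2 furthest off. Compound 4 `Cc1c(NC(=O)CN2C(=O)S/C(=C\c3ccc(Cl)cc3)C2=O)c(=O)n(-c2ccccc2)n1C` differs from compound 3 by chloro in place of bromo on an aromatic carbon and in nothing else. Three measured steps at that carbon bear on it. Bromo in place of methyl gave a modest step (a 2.7-fold lower number from compound 1 to compound 3 (0.43 log units; beyond the scatter)), bromo in place of nitro another (a 3.4-fold lower number from compound 2 to compound 3 (0.53 log units; beyond the scatter)), and nitro in place of methyl none beyond the scatter (a 1.3-fold higher number from compound 1 to compound 2 (0.10 log units; within the scatter)). None of them exchanges bromo for chloro, so they give only a rough outer size. In this assay no step beyond the scatter is expected, only a slight lean toward a higher number. The estimated step is (a 1.3-fold higher number from compound 3 to compound 4 (0.12 log units; within the scatter)). Compound 4 is estimated at 32000 nM with a range from 13000 nM to 70000 nM as the expected span.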

Compound 4, half-maximal inhibitory concentration: 42600 nM
The estimate for compound 4 lay 1.3-fold (0.12 log units) below the measured number, and the stated range covers the measured number.
By their numbers in this assay, from the lowest: compounds 3, 4, 1 and 2 (each within the scatter of the next, the first and the last beyond it).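

In this assay, chloro at this aromatic carbon cannot be told apart from any of the other three groups shown (a 1.8-fold higher number from compound 3 to compound 4 (0.25 log units; within the scatter); a 1.9-fold lower number from compound 2 to compound 4 (0.29 log units; within the scatter); a 1.5-fold lower number from compound 1 to compound 4 (0.19 log units; within the scatter)). The separation that bromo showed from both methyl and nitro therefore does not extend to chloro, so the two halogens do not stand together as a class apart from those groups. The compounds shown leave open how an amine, a carboxylic acid or a longer chain at this carbon would read in this assay. Nothing available speaks to the cause of these numbers.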